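The source may hold more compounds than are shown below. What is called first, only, known or untested is meant among the compounds shown, and "the series" means these compounds.

Working notes on the series.

All three measured compounds sit at the top of an ADME assay on MT2 cells (Homo sapiens) for cytotoxicity, read by MTT assay; a higher number here means that more compound is tolerated, a lower number that less compound is tolerated. Going by the values given here, compound 1 `N#Cc1cc2c(Oc3ccc(F)cc3OCCn3ccc(=O)[nH]c3=O)cccn2c1` is the only one with a number: in this assay compound 1 gives 100000 nM. Compound 2 `N#Cc1ccc2c(Oc3ccccc3OCCn3ccc(=O)[nH]c3=O)cc(F)cc2c1` gives > 100000 nM in this assay, which is a limit of the assay and not a number. Compound 3 `N#Cc1ccc2c(Oc3ccc(F)cc3OCCn3ccc(=O)[nH]c3=O)cc(F)cc2c1` likewise gives > 100000 nM in this assay, again a limit. The step that the two limits leave unreadable from compound 2 to compound 3 is therefore one fluoro in place of hydrogen on an aromatic carbon whose size cannot be read, because both ends rest at the limit of > 100000 nM in this assay, at which 2 of the 3 values shown sit. How the core of compound 1 differs from the core of compound 2 is not broken down here.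

Compound 4 `N#Cc1cc2c(Oc3ccc(F)cc3OCCn3ccc(=O)[nH]c3=O)cc(F)cn2c1` has not been measured in this assay. It differs from compound 1 by fluoro in place of hydrogen on an aromatic carbon. This is the same kind of change as that from compound 2 to compound 3, not the same: there the fluoro entered on a six-membered aromatic ring of carbon only, meta to a large group and para to a large group; here it enters on a six-membered aromatic ring with one nitrogen, part of a fused or bridged system of two rings, two atoms from the ring nitrogen, meta to a fused ring, meta to a large group and para to a fused ring.

From compound 1 to compound 4 a step of no change at the digits printed from compound 1 to compound 4 (within the scatter) is expected, resting on compound 1 at 100000 nM and on the unreadable step that the two limits leave unreadable from compound 2 to compound 3, which gives no sign that this kind of change moves the read-out. Compound 4 is thus estimated at 100000 nM, between 50000 nM and 200000 nM, with a fair chance that only a limit is reported.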

Compound 4, half-maximal cytotoxic concentration: 50000 nM
Compound 4: the middle estimate sits 2.0-fold (0.30 log units) above what was measured, and the stated range covers the measured number.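

In this assay, going by these compounds alone, there is a 2.0-fold lower number from compound 1 to compound 4 (0.30 log units; within the scatter) for fluoro in place of hydrogen on an aromatic carbon of a six-membered aromatic ring with 1 nitrogen, so on the core of compound 1 this change gives no step that stands clear of the scatter. The same kind of change on the core of compound 2 entered on a six-membered aromatic ring of carbon only, and its size cannot be read, so nothing shows whether the change keeps the same size from one core to the other, since both ends of that step rest at a limit: the limit of > 100000 nM in this assay, at which 2 of the 4 values shown sit. What remains is one readable step, on one core and at one place, which sets no pattern for the series.

The compounds shown leave open how the read-out responds to a group other than fluoro on the same aromatic carbon, such as chloro, methoxy or an amine, and to a longer chain in place of the one that joins the two ends of these molecules. They also leave open whether any such change would give a step beyond the scatter in this assay.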